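Swapping the Thiomorpholine Ring for Pyrrolidine

The compounds below may be only part of what the source reports. "The series", "measured", "known", "first", "only" and "open" are said of these compounds alone.

Of the compounds shown here, three built on one shared core have so far been tested in a functional assay on A-431 cells (Homo sapiens) for cytotoxicity, read by MTT assay, with a stated time of 72 h; a higher number here means a weaker inhibitor, a lower number a stronger inhibitor. Compound 1 `Cc1cccc(/C(N)=N/NC(=S)N2CCSCC2)n1` gives 2600 nM, the lowest of the three numbers and therefore the strongest inhibitor among them. Compound 2 `N/C(=N\NC(=S)N1CCSCC1)c1ccccn1` carries hydrogen in place of methyl on an aromatic carbon and gives 6700 nM; the step of a 2.6-fold higher number from compound 1 to compound 2 (0.41 log units; beyond the scatter) is modest but real. Compound 3 `Cc1cccc(/C(N)=N/NC(=S)N2CCCCCC2)n1` differs from compound 1 only in the ring attached to the thiocarbonyl carbon; compound 3 gives 14700 nM, the highest of the three.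

Compound 4 `Cc1cccc(/C(N)=N/NC(=S)N2CCCC2)n1` is not yet measured. It differs from compound 1 by pyrrolidin-1-yl in place of thiomorpholin-4-yl on a thiocarbonyl carbon. Among the measured compounds shown here, the only step measured so far, from compound 1 to compound 2, concerns the aromatic ring and so says little about this change. What does bear on it is the pair of values of compound 1 and compound 3, which show that exchanging the ring on the thiocarbonyl carbon moved the number up. A rise of similar but somewhat smaller size is therefore expected, a 2.3-fold higher number from compound 1 to compound 4 (0.36 log units; beyond the scatter). The estimate for compound 4 is 6000 nM, expected to fall between 2500 nM and 15000 nM.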

Compound 4, half-maximal inhibitory concentration: 4000 nM
Estimate against measurement, compound 4: 1.5-fold (0.18 log units) above, within the range that was stated.
By their numbers in this assay, from the lowest: compounds 1, 4 and 2 (each within the scatter of the next, the first and the last beyond it); then compound 3.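

In this assay, pyrrolidin-1-yl in place of thiomorpholin-4-yl on a thiocarbonyl carbon gives a 1.5-fold higher number from compound 1 to compound 4 (0.19 log units; within the scatter), so this exchange cannot be told apart from no change at all. Among the compounds shown here, the ring sulfur and the six-membered ring of thiomorpholin-4-yl are therefore not needed to keep the number of compound 1 in this assay, a finding the earlier compounds could not give, since the only ring exchange among them, in compound 3, came with a clearly higher printed value of 14700 nM, whereas compound 4 gives 4000 nM. Not every ring at this place is thus equal, yet nothing at hand offers a measured reason for the difference between these rings.

Still open, on these data alone, is how a morpholin-4-yl ring, with oxygen where thiomorpholin-4-yl has sulfur, or an open-chain dimethylamino group would behave on the same thiocarbonyl carbon. Also open, as far as these compounds go, is whether hydrogen in place of methyl on the aromatic carbon would shift the number in the same way when pyrrolidin-1-yl sits on the thiocarbonyl carbon.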